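The compounds below may be only part of what the source reports. "The series", "measured", "known", "first", "only" and "open" are said of these compounds alone.

Measured so far in an ADME assay on HEK293 cells (Homo sapiens) for cytotoxicity, read by resazurin assay, with a stated time of 48 h; a higher number here means that more compound is tolerated, a lower number that less compound is tolerated:
compound 1, `CS(=O)(=O)Nc1ccc(-c2nc3ccccc3o2)cc1`: > 100000 nM
compound 2, `O=S(=O)(Nc1ccc2oc(-c3ccccc3)nc2c1)c1ccccc1F`: 72000 nM

Compound 1 stands only at a limit of this assay, not at a number, since its value is recorded as the limit of > 100000 nM in this assay, at which 1 of the 2 values shown sits. Where exactly compound 1 sits within or beyond that limit is not known. Among the compounds with values here, compound 2 gives a finite reading in this assay, 72000 nM, and is the only compound with a number.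

Compound 3, `O=S(=O)(Nc1ccc(-c2nc3ccccc3o2)cc1)c1ccc(Cl)cc1`, is not yet measured. It differs from compound 1 in one place: 4-chlorophenyl in place of methyl on a sulfonyl sulfur. Within the data shown here, no step between two measured compounds covers a change of this kind, so its size has to be guessed. Since compound 2, which also bears a larger group on its sulfonyl sulfur, sits at a finite value near the limit, a small step toward less tolerated compound, or none beyond the scatter, is expected: an at least 1.4-fold lower number from compound 1 to compound 3 (0.15 log units; that floor lies within the scatter). Compound 3 is therefore estimated at 70000 nM, between 30000 nM and 150000 nM, with a fair chance that only a limit is reported.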

Compound 3, half-maximal cytotoxic concentration: > 100000 nM
Compound 3: a limit, no number (the forecaster's own chance of this, stated with the estimate: 35%); middle value at least 1.4-fold (0.15 log units) away from the limit.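

In this assay no step can be read from compound 1 to compound 3, because both are recorded only as a limit: the limit of > 100000 nM in this assay, at which 2 of the 3 values shown sit.

The compounds shown leave open whether 4-chlorophenyl in place of methyl on a sulfonyl sulfur changes the tolerated concentration at all.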